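A few compounds are considered here, and "the series" means these few. Any claim that something is new, unique, unknown or untested is made for them only; others in the source may bear on it.

Measured so far:
compound 1 `O=c1nc2oc(-c3cccc(O)c3)cc2cn1[C@H]1C[C@H](O)[C@@H](CO)O1` — > 500000 nM
compound 2 `O=c1nc2oc(-c3ccccc3F)cc2cn1C1C[C@H](O)[C@@H](CO)O1` — > 500000 nM

In an assay on isolated protein for inhibition of thymidine kinase, cytosolic (Homo sapiens) (on this read-out lower numbers stand for stronger inhibition and higher numbers for weaker inhibition), compound 1 reports > 500000 nM, a limit of the assay and not a number. Compound 2 likewise sits at > 500000 nM, again a limit. Both values therefore rest on (the limit of > 500000 nM in this assay, at which 2 of the 2 values shown sit), so compound 1 has no measured place within the series beyond that limit. Compound 3 `O=c1nc2oc(-c3ccc(F)cc3)cc2cn1[C@H]1C[C@H](O)[C@@H](CO)O1` carries the change (4-fluorophenyl in place of 3-hydroxyphenyl on an aromatic carbon). Going by the values given here, with no measured step to compare, the step from compound 1 to compound 3 is expected to be none beyond the scatter, so a step that the limit leaves unreadable from compound 1 to compound 3. Compound 3 is estimated at 800000 nM, ranging from 300000 nM to 3000000 nM, most likely returned as a limit.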

Compound 3, half-maximal inhibitory concentration: > 500000 nM
Compound 3 gave a limit, no number; the forecaster's own chance of this, stated with the estimate: 85%; the middle value does not contradict the limit.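

In this assay no step can be read between compound 1 and compound 3, since both values are limits and not numbers: the limit of > 500000 nM in this assay, at which 3 of the 3 values shown sit.
As far as these compounds go, whether any substituted phenyl group on the shared core gives a number rather than a limit in this assay stays open.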